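Propyl in place of hydrogen: expected read-out for compound 3

The source may hold more compounds than are shown below. What is called first, only, known or untested is meant among the compounds shown, and "the series" means these compounds.

Compound 1 `O=C(Nc1nn[nH]n1)c1cc(Cl)cc(-c2ccccc2)n1` gives 40% in a functional assay on the whole organism with Rattus norvegicus as the target, at a dose of 1 mg/kg by the oral route; a lower number here means a weaker effect, a higher number a stronger effect of the compound at the dose given. Within the data shown here, of the two measured numbers, compound 1 sits at the low end, but its only neighbour, compound 2 `CCc1ccc(-c2cc(Cl)cc(C(=O)Nc3nn[nH]n3)n2)cc1` with 49%, lies within the scatter of it, as the step of a number 9 percentage points higher from compound 1 to compound 2 (within the scatter) shows.

Compound 3 `CCCc1ccc(-c2cc(Cl)cc(C(=O)Nc3nn[nH]n3)n2)cc1` has not yet been measured. It differs from compound 1 by propyl in place of hydrogen on an aromatic carbon.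

Among the measured compounds shown here, the one measured step that bears on this change is the step from compound 1 to compound 2, ethyl in place of hydrogen at the same position, which stayed within the scatter. Lengthening the chain further to propyl therefore gives no basis for expecting a step beyond the scatter in this assay; at most a small rise in the same direction is anticipated.

For compound 3 the estimated value is 50%, with a range of 35% to 65%. The expected step of a number 10 percentage points higher from compound 1 to compound 3 (within the scatter) is thus small and of uncertain sign.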

Compound 3, a percentage reported as inhibition, in the whole organism at one dose (the size of the read-out at that dose, not a potency): 78%
For compound 3 the middle estimate is 28 percentage points below the measured one; measured number outside the range, above it.
By their numbers in this assay, from the lowest: compounds 1 and 2 (each within the scatter of the next); then compound 3.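

In this assay, propyl on this aromatic carbon, para to a large group, gives a number 38 percentage points higher from compound 1 to compound 3 (beyond the scatter), so a change at this position can move the read-out beyond the scatter, which the ethyl step had not shown. The extra methyl on the saturated chain carbon, two bonds along the chain from an aromatic carbon, gives a number 29 percentage points higher from compound 2 to compound 3 (beyond the scatter), so among these compounds the difference between ethyl and propyl separates a step within the scatter from one beyond it. Nothing at hand accounts for this rise.

As far as these compounds go, whether a longer chain such as butyl extends the rise or reverses it remains open, as does the outcome with a branched isopropyl or a methoxy group on the same carbon. The read-out at one oral dose also gives no potency for any of these compounds.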